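Second chloro on the benzamide ring of compound 3

The source may report more compounds than this note shows. Statements on the series, on what has been measured and on what is new or still open speak of the compounds shown alone.

Compound 3 `O=C(Nc1ccc(Cl)c(-c2nnc3c(Cl)cccn23)c1)c1ccccc1Cl` gives 83800 nM in a functional assay on T47D cells (Homo sapiens) for antiproliferative activity, read by MTT assay, with a stated time of 72 h; on this read-out lower numbers stand for stronger inhibition and higher numbers for weaker inhibition. On the numbers in hand this is the highest of the two; the nearest is compound 1 `O=C(Nc1ccc(Cl)c(-c2nnc3c(Cl)cccn23)c1)c1ccc(C(F)(F)F)cc1F`, which in this assay gives 70800 nM, a gap that lies within the scatter. Compound 2 `O=C(Nc1ccc(Cl)c(-c2nnc3c(Cl)cccn23)c1)c1ccccc1` in this assay reaches only > 100000 nM, which is the limit of > 100000 nM in this assay, at which 1 of the 3 values shown sits, and not a number.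

Compound 4 `O=C(Nc1ccc(Cl)c(-c2nnc3c(Cl)cccn23)c1)c1ccc(Cl)cc1Cl` is not yet measured. It differs from compound 3 in one place: chloro in place of hydrogen on an aromatic carbon. Going by the values given here, the only measured step of the same kind on this ring is an at least 1.1-fold lower number from compound 2 to compound 3 (0.07 log units; that floor lies within the scatter); since it starts from a limit, it fixes only a floor, and that floor sits within the scatter. Every read in this assay for the three measured compounds is weak, and the added chloro gives no ground for a shift beyond the scatter. The expected step is therefore a 1.3-fold lower number from compound 3 to compound 4 (0.11 log units; within the scatter), a slight lowering at most, with a real chance that compound 4 again returns only a limit.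

Compound 4 is estimated to give 65000 nM in this assay, with a range of 30000 nM to 150000 nM.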

Compound 4, half-maximal inhibitory concentration: > 100000 nM
Compound 4: only a limit was reported; the forecaster's own chance of this, stated with the estimate: 30%; middle value at least 1.5-fold (0.18 log units) away from the limit.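

Compound 4 gives > 100000 nM in this assay, which is a limit of the assay and not a number. The step is an at least 1.1-fold higher number from compound 3 to compound 4 (0.07 log units; that floor lies within the scatter), so adding a chloro at this position, para to a large group and meta to the existing chloro group, brings no lowering of the number; going from 2-chlorophenyl to 2,4-dichlorophenyl gives no sign of a gain in this assay, although the opening pair alone could not exclude one. The step from compound 2 to compound 4 cannot be read, as both compounds rest on the same limit: the limit of > 100000 nM in this assay, at which 2 of the 4 values shown sit.

The compounds shown leave open whether a different kind of group at this position, such as an amine, a carboxylic acid or a methoxy group, would bring a read clearly under the limit. As far as these compounds go, how far compound 2 and compound 4 lie past the limit also stays unknown, and with it any order between the two.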